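Swapping the Benzyl Ring of Compound 1 for Thiophene

The source may report more compounds than this note shows. Statements on the series, on what has been measured and on what is new or still open speak of the compounds shown alone.

Compound 1 `Cc1nc2c(OCc3ccccc3)cccn2c1N` is the reference. In a functional assay on the whole organism with Canis familiaris (Canis lupus familiaris) as the target, at a dose of 2 mg/kg by the intravenous route (a higher number here means a stronger effect of the compound at the dose given, a lower number a weaker effect), compound 1 gives 97%, the highest of the three numbers, though compound 3 sits within the scatter of it. Compound 3 `Cc1nc2c(OCc3ccc(F)cc3)cccn2c1N` gives 95%, and compound 2 `Nc1cnc2c(OCc3ccccc3)cccn12` gives 81%. The step of a number 2 percentage points lower from compound 1 to compound 3 (within the scatter) stays within the scatter, whereas the step of a number 16 percentage points lower from compound 1 to compound 2 (beyond the scatter) is a modest loss. Compound 4 `Cc1nc2c(OCc3ccsc3)cccn2c1N` differs from compound 1 by thiophen-3-yl in place of phenyl on a saturated chain carbon bound to an oxygen on an aromatic ring. Among the measured compounds shown here, only the step from compound 1 to compound 3 touches the same ring, and it was flat; the loss of the methyl concerns another part of the molecule. A step of a number 6 percentage points lower from compound 1 to compound 4 (within the scatter) is therefore expected, at most a small drop. Compound 4 is estimated to give 91%, between 76% and 99%.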

Compound 4, a percentage reported as inhibition, in the whole organism at one dose (the size of the read-out at that dose, not a potency): 82%
Estimate against measurement, compound 4: 9 percentage points above; measured number inside the range.
By their numbers in this assay, from the lowest: compounds 2 and 4 (each within the scatter of the next); then compounds 3 and 1 (each within the scatter of the next).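

The swap of phenyl for thiophen-3-yl gives a number 15 percentage points lower from compound 1 to compound 4 (beyond the scatter) and so shows that this ring cannot be exchanged without cost. The fluoro change on the same ring gave only a number 2 percentage points lower from compound 1 to compound 3 (within the scatter) and did not reveal this. No available measurement explains the loss.

Going by these compounds, it remains open whether the loss is particular to thiophen-3-yl or extends to other replacements for phenyl. A pyridin-3-yl or cyclohexyl group on the same chain carbon would help separate these possibilities.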